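Swapping an Aryloxymethyl Amide onto a Piperazine Core

The source may hold more compounds than are shown below. What is called first, only, known or untested is meant among the compounds shown, and "the series" means these compounds.

Measured compounds:
- compound 1, `CC(C)C[C@H](N)c1cc(C(F)(F)F)ccc1N1CCN(C(=O)C(C)Cc2ccc(Cl)cc2O)CC1`: 36 nM
- compound 2, `CC(C)C[C@H](N)c1cc(C(F)(F)F)ccc1N1CCN(C(=O)COc2ccc3ccccc3c2)CC1`: 2000 nM
- compound 3, `CC(C)C[C@H](N)c1cc(C(F)(F)F)ccc1N1CCN(C(=O)[C@H](C)Cc2ccc(Cl)cc2)CC1`: 31 nM

All three share the same core and differ only in the group attached to the amide carbonyl. In an assay on HEK293 cells for displacement of a labelled ligand from Melanocortin receptor 4 (Homo sapiens) (on this read-out higher numbers stand for weaker inhibition and lower numbers for stronger inhibition), compound 1 gives 36 nM, the second highest of the three numbers; compound 3 sits within the scatter of it, while compound 2 lies far away with a 56-fold higher number from compound 1 to compound 2 (1.74 log units; beyond the scatter).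

Compound 4, `CC(C)C[C@H](N)c1cc(C(F)(F)F)ccc1N1CCN(C(=O)COc2ccc([N+](=O)[O-])cc2)CC1`, has not yet been measured. It differs from compound 1 in one place: (4-nitrophenoxy)methyl in place of 1-(4-chloro-2-hydroxybenzyl)ethyl on a carbonyl carbon.

Among the measured compounds shown here, the step that bears most directly on this change is the one from compound 1 to compound 2, where the same group left and an aryloxymethyl entered, and the number rose sharply: a 56-fold higher number from compound 1 to compound 2 (1.74 log units; beyond the scatter). The reverse comparison, a 65-fold lower number from compound 2 to compound 3 (1.81 log units; beyond the scatter), points the same way. Compound 4 carries an aryloxymethyl of the same kind, so a large rise in this assay is expected because the comparable step a 56-fold higher number from compound 1 to compound 2 (1.74 log units; beyond the scatter) was large. Compound 4 is therefore expected to give about 1500 nM, with a range from 400 nM to 6000 nM. The expected step is a 42-fold higher number from compound 1 to compound 4 (1.62 log units; beyond the scatter).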

Compound 4, inhibition constant: 3100 nM
The estimate for compound 4 lay 2.1-fold (0.32 log units) below the measured number, within the range that was stated.
By their numbers in this assay, from the lowest: compounds 3 and 1 (each within the scatter of the next); then compounds 2 and 4 (each within the scatter of the next).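

In this assay, a second aryloxymethyl amide now lands far from the two benzyl-type amides, with an 86-fold higher number from compound 1 to compound 4 (1.94 log units; beyond the scatter) and a 100-fold higher number from compound 3 to compound 4 (2.00 log units; beyond the scatter), so the large shift seen earlier is no longer tied to a single compound. The aryl group on the oxygen can also change a good deal without a clear effect: replacing naphthalen-2-yl with 4-nitrophenyl gives a 1.6-fold higher number from compound 2 to compound 4 (0.19 log units; within the scatter), a step that stays within the scatter. Across these four compounds, the weaker numbers go with the aryloxymethyl unit rather than with one particular aryl group, and none of the four goes against this, although only compounds 2 and 4 carry that unit.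

Nothing available here explains the gap between the two pairs of compounds. Going by these compounds, it also remains open whether the ether oxygen or the aryl group matters more: a 2-(4-nitrophenyl)ethyl group, with carbon in place of that oxygen, or a (4-chlorophenoxy)methyl group, which keeps the oxygen and carries the chlorine of compounds 1 and 3, could fall with either pair.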